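This account rests on a few compounds, and the source may have more. Where it says the series, first, only, none or still open, it means among the compounds named here.

Measured compounds in a functional assay on KBVIN cells (Homo sapiens) for antiproliferative activity, read by sulforhodamine B assay, with a stated time of 3 days; a lower number here means that less compound is needed, a higher number that more compound is needed for the effect:
- compound 1 `CCC1=C(O)c2c(oc(-c3ccc(C)c(Cl)c3)cc2=O)C(CC)(CC)C1=O`: 2.15 uM
- compound 2 `CCC1=C(O)c2c(oc(-c3ccc(C)c(F)c3)cc2=O)C(CC)(CC)C1=O`: 2.95 uM
- compound 3 `CCC1=C(O)c2c(oc(-c3ccc(OC)c(F)c3)cc2=O)C(CC)(CC)C1=O`: 0.1 uM

The three compounds share one core and differ only in the aryl group attached to it. Compound 2 and compound 1 differ by chloro in place of fluoro on an aromatic carbon, and in this assay this gives a 1.4-fold lower number from compound 2 to compound 1 (0.14 log units; within the scatter). Compound 3 differs from compound 2 by methoxy in place of methyl on an aromatic carbon, and that change gives a 30-fold lower number from compound 2 to compound 3 (1.47 log units; beyond the scatter). Compared with compound 1, compound 3 shows a 22-fold lower number from compound 1 to compound 3 (1.33 log units; beyond the scatter). Compound 3 thus has the lowest number of the three, and both of its steps to the others lie beyond the scatter.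

Compound 4 `CCC1=C(O)c2c(oc(-c3ccc(OC)c(Cl)c3)cc2=O)C(CC)(CC)C1=O` has not yet been measured. It differs from compound 3 by chloro in place of fluoro on an aromatic carbon. Within the data shown here, this is the same kind of change as the one from compound 2 to compound 1, though not the same: in that pair the exchanged atom sits ortho to a methyl group (1 heavy atom), whereas here it sits ortho to a methoxy group (2 heavy atoms).

The expected step, a 1.3-fold lower number from compound 3 to compound 4 (0.10 log units; within the scatter), rests on the earlier exchange, because a 1.4-fold lower number from compound 2 to compound 1 (0.14 log units; within the scatter) stayed within the scatter. Compound 4 is therefore estimated to give 0.08 uM in this assay, with a likely range from 0.03 uM to 0.2 uM.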

Compound 4, concentration for half-maximal effect: 1.37 uM
The estimate for compound 4 lay 17-fold (1.23 log units) below the measured number; measured number above the stated range.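

In this assay, the exchange of fluoro for chloro did not carry from one core to the other, since a 14-fold higher number from compound 3 to compound 4 (1.14 log units; beyond the scatter) stands against a step within the scatter on the methyl-bearing core: the same change on two cores in this assay, a 1.4-fold lower number (0.14 log units; within the scatter) from compound 2 to compound 1 and a 14-fold higher number (1.14 log units; beyond the scatter) from compound 3 to compound 4, 19-fold (1.27 log units) apart, beyond the scatter of two such steps Methoxy in place of methyl likewise depended on the halogen the ring carries, giving only a 1.6-fold lower number from compound 1 to compound 4 (0.20 log units; within the scatter) with chloro present, in contrast to the much larger step with fluoro: the same change on two cores in this assay, a 30-fold lower number (1.47 log units; beyond the scatter) from compound 2 to compound 3 and a 1.6-fold lower number (0.20 log units; within the scatter) from compound 1 to compound 4, 19-fold (1.27 log units) apart, beyond the scatter of two such steps Making both changes at once gives a 2.2-fold lower number from compound 2 to compound 4 (0.33 log units; beyond the scatter), so in these four compounds the size of either step could not be read from its counterpart on the other core, although this does not show why the steps differ, nor does it give a rule for any other aryl group.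

The compounds shown leave open whether the low number of compound 3, 0.1 uM, belongs only to the combination of fluoro and methoxy, or would also appear with bromo in place of the fluoro or with ethoxy or an amine in place of the methoxy. They also leave open whether the same dependence would hold if the ethyl groups of the shared core gave way to a longer chain.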